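Cyclopropyl for phenyl on the carbonyl of compound 2

This account rests on a few compounds, and the source may have more. Where it says the series, first, only, none or still open, it means among the compounds named here.

In a functional assay on PC-3 cells (Homo sapiens) for inhibition, read by MTT assay, with a stated time of 48 h (on this read-out higher numbers stand for weaker inhibition and lower numbers for stronger inhibition), compound 1 `COc1ccc(CSc2nnc(-c3cc(OC)c(OC)c(OC)c3)n2-c2ccc(OC)cc2)cc1` gives 40300 nM as its reading. Compound 2 `COc1ccc(-n2c(SCC(=O)c3ccccc3)nnc2-c2cc(OC)c(OC)c(OC)c2)cc1` gives > 60000 nM as a limit of the assay and not a number. The place of compound 2 is the limit of > 60000 nM in this assay, at which 1 of the 2 values shown sits, and nothing firmer. Compound 3 `COc1ccc(-n2c(SCC(=O)C3CC3)nnc2-c2cc(OC)c(OC)c(OC)c2)cc1` carries cyclopropyl in place of phenyl on a carbonyl carbon in the same side chain. Going by the values given here, the one measured step on that chain is an at least 1.4-fold higher number from compound 1 to compound 2 (0.17 log units; that floor lies within the scatter) and it shows no size beyond the scatter. No step beyond the scatter is therefore expected in this assay and no direction is favoured. The estimated step is an at least 1.0-fold lower number from compound 2 to compound 3 (0.03 log units; that floor lies within the scatter) and is expected to stay within the scatter. Compound 3 is estimated at 55000 nM (range 25000 nM to 120000 nM) and may well read only as a limit.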

Compound 3, half-maximal inhibitory concentration: 37200 nM
For compound 3 the middle estimate is 1.5-fold (0.17 log units) above the measured one; measured number inside the range.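

In this assay, cyclopropyl in place of phenyl on a carbonyl carbon gives an at least 1.6-fold lower number from compound 2 to compound 3 (0.20 log units; that floor lies within the scatter), so a carbonyl side chain can give a number and not only a limit. The change of side chain gives a 1.1-fold lower number from compound 1 to compound 3 (0.03 log units; within the scatter), so these two side chains cannot be told apart here. Compound 2 remains a limit of the assay and not a number, so its step stays a floor: the limit of > 60000 nM in this assay, at which 1 of the 3 values shown sits.

No step shown goes beyond the scatter. Going by these compounds, whether an amine, a carboxylic acid or a longer chain in this side chain would do so stays open.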